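The source may hold more compounds than are shown below. What is called first, only, known or untested is meant among the compounds shown, and "the series" means these compounds.

Measured so far, all in an assay on isolated protein for inhibition of tyrosine-protein kinase receptor UFO (Homo sapiens), read by ELISA; on this read-out lower numbers stand for stronger inhibition and higher numbers for weaker inhibition:
- compound 1 `Cn1cc(-c2ccc(NC(=O)c3cn(CC4CCOCC4)cc(-c4ccc(Cl)cc4)c3=O)cc2)c2c(N)ncnc21`: 0.2 nM
- compound 2 `CN(C)C(=O)Cn1cc(C(=O)Nc2ccc(-c3cn(C)c4ncnc(N)c34)cc2)c(=O)c(-c2ccc(F)cc2)c1`: 0.5 nM
- compound 3 `CN(C)CCn1cc(-c2ccc(NC(=O)c3cn(CC4CCOCC4)cc(-c4ccc(F)cc4)c3=O)cc2)c2c(N)ncnc21`: 2.8 nM

Among these three, compound 1 has the lowest number in this assay, which means the strongest inhibition. Compound 2 comes nearest, with a higher number, a gap that lies beyond the usual scatter of repeated measurements. Compound 3 stands furthest away, with a number well above that of compound 1, again clearly beyond the scatter. No two of these compounds differ in only one place, so none of these gaps can be tied to a single structural change.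

Compound 4 `Cn1cc(-c2ccc(NC(=O)c3cn(CC4CCOCC4)cc(-c4ccc(C(F)(F)F)cc4)c3=O)cc2)c2c(N)ncnc21` has not yet been measured. It is derived from compound 1 by a single change: trifluoromethyl in place of chloro on an aromatic carbon. The rest of the molecule is kept unchanged.

Within the data shown here, since no single-change step between measured compounds is available, the expectation for this step rests on the general experience that a swap of this kind tends to move the number only a little. The step from compound 1 to compound 4 in this assay is expected to be small, a 2.0-fold higher number from compound 1 to compound 4 (0.30 log units; within the scatter), most likely toward a slightly higher number, close to the edge of the scatter. Compound 4 is therefore estimated at 0.4 nM in this assay, with a likely range from 0.1 nM to 1.5 nM.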

Compound 4, half-maximal inhibitory concentration: 0.4 nM
Compound 4: middle estimate and measured number agree at the digits printed; low and high end bracket the measured number.
By their numbers in this assay, from the lowest: compounds 1, 4 and 2 (each within the scatter of the next, the first and the last beyond it); then compound 3.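

In this assay, among these compounds, trifluoromethyl on the aromatic carbon para to a large group, in place of chloro, gives a 2.0-fold higher number from compound 1 to compound 4 (0.30 log units; within the scatter), and this is the first gap that can be tied to one structural change. The change replaces 1 heavy atom with 4 heavy atoms, neither group carrying a hydrogen-bond donor, a hydrogen-bond acceptor or a net charge, and the read-out stays within the usual scatter of repeated measurements, so this position accepts the bulkier of the two groups without a measurable loss of inhibition. The earlier compounds shown here could not show this, since no two of them differed in only one place, and the finding rests on this single pair in this single assay.

Among the compounds shown here, whether the same position would accept a group of a different kind, such as an amine, a carboxylic acid, a nitrile or a longer alkyl chain, stays open, since chloro and trifluoromethyl are the only two groups compared here on an otherwise identical molecule. Nothing in the available data explains why these two groups give matching results.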